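A few compounds are considered here, and "the series" means these few. Any claim that something is new, unique, unknown or untested is made for them only; others in the source may bear on it.

Compound 1 `Nc1ccccc1NC(=O)/C=C/c1ccc(Cn2cnc3c(Nc4ccccc4)nc(Cl)nc32)cc1`: in a functional assay on HepG2 cells (Homo sapiens) for antiproliferative activity, read by CCK-8 assay, with a stated time of 72 h, tested at 2 uM (on this read-out higher numbers stand for a stronger effect at the one concentration tested and lower numbers for a weaker effect), compound 1 gives 16.4%.
Compound 2 `CCC(C)n1cnc2c(NCc3ccc(C(=O)Nc4ccccc4N)cc3)nc(Cl)nc21`: compound 2 gives 45%.
Compound 3 `Nc1ccccc1NC(=O)c1ccc(Cn2cnc3c(NCc4ccccc4)nc(Cl)nc32)cc1`: compound 3 gives 7.55%.

Compound 2 stands highest of the three numbers. Compound 1 is nearest to it, with a lower number beyond the scatter, and compound 3 is furthest, also beyond the scatter. Compound 4 `Nc1ccccc1NC(=O)c1ccc(CNc2nc(Cl)nc3c2ncn3C2CCCC2)cc1` has not yet been measured. It differs from compound 2 in one place: cyclopentyl in place of sec-butyl on an aromatic nitrogen. For the measured compounds named here, no pair of measured compounds differs in one place only, so nothing measured shows what this swap does. Since the exchange replaces one small carbon-only group with a closely related one, the expected step in this assay is none beyond the scatter, in either direction. Compound 4 is therefore estimated to give 42%, within 25% to 60%, an expected step of a number 3 percentage points lower from compound 2 to compound 4 (within the scatter).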

Compound 4, a percentage reported as inhibition, at one concentration (the size of the read-out at that concentration, not a potency): 54.7%
Compound 4: the middle estimate sits 12.7 percentage points below what was measured; low and high end bracket the measured number.
By their numbers in this assay, from the lowest: compounds 3 and 1 (each within the scatter of the next); then compounds 2 and 4 (each within the scatter of the next).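

In this assay, for the compounds shown here, putting cyclopentyl in place of sec-butyl on the aromatic nitrogen gives a number 9.7 percentage points higher from compound 2 to compound 4 (within the scatter) and so offers the first direct reading at this position: closing the carbon group into a five-membered ring leaves the effect unchanged within the usual scatter. Nothing measured here explains this result. From the compounds shown here alone, what remains open is how far this position tolerates other groups, such as a methyl, a longer carbon chain or a chain ending in an amine, and whether any of them would move the effect beyond the scatter.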